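A New Alkyne Chain on the Deoxyuridine Core

The compounds below may be only part of what the source reports. "The series", "measured", "known", "first", "only" and "open" are said of these compounds alone.

This study follows one change on a small set of pyrimidine nucleosides, tested for their power to block the growth of mouse leukemia cells. In a functional assay on L1210 cells (Mus musculus) (on this read-out higher numbers stand for weaker inhibition and lower numbers for stronger inhibition), compound 1 `C#Cc1cn(C2O[C@H](CO)[C@@H](O)[C@@H]2O)c(=O)[nH]c1=O` gives 45 ug/mL. Compound 2 `CC#CCc1cn([C@H]2C[C@H](O)[C@@H](CO)O2)c(=O)[nH]c1=O` reaches only the limit of > 1000 ug/mL in this assay, so it stands at the limit of > 1000 ug/mL in this assay, at which 1 of the 2 values shown sits, and no exact number is known for it. The next compound, compound 3 `CC(C)(C)C#Cc1cn([C@H]2C[C@H](O)[C@@H](CO)O2)c(=O)[nH]c1=O`, differs from compound 2 in one place: 3,3-dimethylbut-1-yn-1-yl in place of but-2-yn-1-yl on an aromatic carbon. For the measured compounds named here, since compound 2 sits at a limit, no step between measured compounds is available to guide the expectation, and the only number at hand is that of compound 1 in this assay. The step from compound 2 to compound 3 is expected to move toward stronger inhibition, roughly an at least 3.3-fold lower number from compound 2 to compound 3 (0.52 log units; beyond the scatter), though the uncertainty is wide. For compound 3 the estimated value in this assay is 300 ug/mL, with a plausible range from 50 ug/mL to 1000 ug/mL.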

Compound 3, concentration for 50% inhibition: 287 ug/mL
Estimate against measurement, compound 3: 1.0-fold (0.02 log units) above, and the stated range covers the measured number.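

On this aromatic carbon, the swap of but-2-yn-1-yl for 3,3-dimethylbut-1-yn-1-yl brings the deoxyuridine series from no exact reading to a measurable one in this assay, with an at least 3.4-fold lower number from compound 2 to compound 3 (0.54 log units; beyond the scatter). The position therefore tolerates a change in the alkyne chain that shifts the read-out, and both chains carry one triple bond, so that count alone does not set the result. The true size of the step stays unknown, since one end of it is only a limit and not a number: the limit of > 1000 ug/mL in this assay, at which 1 of the 3 values shown sits.

The compounds shown cannot separate the effect of the two extra carbons from that of their branching or of where the triple bond sits in the chain. A straight hex-1-yn-1-yl chain, or an alkyne chain ending in an amine or a carboxylic acid, would test how far this trend extends.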